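Reversed amide with fluoropiperidine on the pyrazole carbon

This account rests on a few compounds, and the source may have more. Where it says the series, first, only, none or still open, it means among the compounds named here.

Of the compounds shown here, two sharing a benzofuran-derived core have been measured in an assay on CHO-K1 cells for displacement of a labelled ligand from prostaglandin E2 receptor EP1 subtype (Homo sapiens), read by scintillation counting, with a stated time of 45 min; on this read-out higher numbers stand for weaker inhibition and lower numbers for stronger inhibition. Compound 1 `Cc1cc(C(=O)O)nn1Cc1cc(Cl)cc2cc(C3CCCCC3)oc12` gives 3.98 nM in this assay. Compound 2 `Cc1cc(C(=O)NC(C)C)nn1Cc1cc(Cl)cc2cc(-c3ccccc3)oc12` gives 10 nM in this assay, the higher of the two numbers, and its nearest neighbour, compound 1, sits a step below it that lies beyond the usual scatter. Compound 3 `Cc1cc(NC(=O)C2(F)CCNCC2)nn1Cc1cc(Cl)cc2cc(-c3ccccc3)oc12` is not yet measured; it differs from compound 2 by ((4-fluoropiperidin-4-yl)carbonyl)amino in place of isopropylcarbamoyl on an aromatic carbon, so the carbamoyl is turned around into an amide bearing a six-membered ring with one nitrogen and a fluorine. Among the compounds with values here, no measured pair shows a step of this kind, so the direction must be guessed from the change alone. Compound 3 is expected to give 20 nM in this assay, within a range from 5 nM to 80 nM. This estimate means a step of a 2.0-fold higher number from compound 2 to compound 3 (0.30 log units; within the scatter), expected to be small and toward a higher number.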

Compound 3, half-maximal inhibitory concentration: 39.8 nM
Compound 3: middle estimate off by 2.0-fold (0.30 log units), on the low side, within the range that was stated.
By their numbers in this assay, from the lowest: compound 1; then compound 2; then compound 3.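

In this assay, within the data shown here, placing ((4-fluoropiperidin-4-yl)carbonyl)amino in place of isopropylcarbamoyl on this aromatic carbon gives a 4.0-fold higher number from compound 2 to compound 3 (0.60 log units; beyond the scatter) and is the first single-place step read here, showing that the number at this position depends on the group it carries. The change turns the amide around and also brings in a six-membered non-aromatic ring and a fluorine, so this one step cannot divide its size among those parts. No measurement shown bears on the reason for the step.

As far as these compounds go, it remains open whether a turned-around amide carrying isopropyl, or a piperidine without the fluorine, would read closer to compound 2. From the compounds shown here alone, how a simple primary amine on this same carbon would read also remains open.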